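The source may report more compounds than this note shows. Statements on the series, on what has been measured and on what is new or still open speak of the compounds shown alone.

Working notes on the trimethoxyphenyl-triazole series.

Of the compounds shown here, two have been measured in a functional assay on Jurkat cells (Homo sapiens) for antiproliferative activity, read by MTT assay, with a stated time of 72 h; on this read-out lower numbers stand for stronger inhibition and higher numbers for weaker inhibition. Compound 1, `COc1cc(-c2ncnn2-c2ccc(Cl)c(Cl)c2)cc(OC)c1OC`, pairs the shared core with a dichlorophenyl ring. In this assay compound 1 reaches only the assay limit, > 10000 nM, so no number is available for it. Compound 2, `COc1cc(-n2ncnc2-c2cccc(F)c2)cc(OC)c1OC`, carries a 3-fluorophenyl ring on the core instead. In this assay compound 2 also sits at the limit, > 10000 nM, and again no number is known. Compound 2 therefore cannot be placed relative to compound 1: both values are limits and show only that neither reached the measurable range, as summarised by the limit of > 10000 nM in this assay, at which 2 of the 2 values shown sit.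

The next compound, compound 3, `COc1cccc(-c2ncnn2-c2cc(OC)c(OC)c(OC)c2)c1`, differs from compound 2 in one place: methoxy in place of fluoro on an aromatic carbon. Nothing measured in the series yet separates one aryl substituent from another, since every value shown is a limit.

With both measured compounds at the limit, no step beyond the usual scatter is expected for compound 3 in this assay, and the step from compound 2 to compound 3 is estimated as a step that the limit leaves unreadable from compound 2 to compound 3. Compound 3 is expected to give about 20000 nM in this assay, within a range from 3000 nM to 100000 nM, most likely reported again as a limit.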

Compound 3, half-maximal inhibitory concentration: > 10000 nM
Compound 3: no number, only a limit (the forecaster's own chance of this, stated with the estimate: 70%); the middle value does not contradict the limit.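

In this assay, going by these compounds alone, compound 3 gives only a limit, as compound 2 does, so no step between compound 2 and compound 3 can be read and the swap of methoxy for fluoro stays unsized: the limit of > 10000 nM in this assay, at which 3 of the 3 values shown sit.

The compounds shown leave open whether any aryl substituent on the shared core brings activity into the measurable range.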